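Methoxy in place of chloro: compound 2 to compound 3

The source may report more compounds than this note shows. Statements on the series, on what has been measured and on what is new or still open speak of the compounds shown alone.

- compound 1 `O=C(Nc1ccccc1NC(=O)C(Cl)Cl)C(Cl)Cl`: 131000 nM
- compound 2 `O=C(Nc1cccc(Cl)c1)C(Cl)Cl`: 14800 nM

In a functional assay on A549 cells (Homo sapiens) for antiproliferative activity, read by MTT assay, with a stated time of 72 h (a higher number here means a weaker inhibitor, a lower number a stronger inhibitor), compound 2 gives the lower of the two numbers, and the gap up to compound 1 lies beyond the scatter. Compound 3 `COc1cccc(NC(=O)C(Cl)Cl)c1` carries methoxy in place of chloro on an aromatic carbon, meta to a group of 6 heavy atoms (methoxy in place of chloro on an aromatic carbon). Going by the values given here, no measured pair shows this change, so its size is not known from the series. The expected 2.2-fold higher number from compound 2 to compound 3 (0.33 log units; beyond the scatter) is a modest move to a higher number, near the edge of the scatter. For compound 3 the estimated value is 32000 nM, within an expected range of 11000 nM to 95000 nM.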

Compound 3, half-maximal inhibitory concentration: 25800 nM
The estimate for compound 3 lay 1.2-fold (0.09 log units) above the measured number; low and high end bracket the measured number.
By their numbers in this assay, from the lowest: compounds 2 and 3 (each within the scatter of the next); then compound 1.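

On the aromatic carbon meta to a group of 6 heavy atoms, methoxy in place of chloro gives a 1.7-fold higher number from compound 2 to compound 3 (0.24 log units; within the scatter) in this assay. This first step at the position shows that the exchange, with two heavy atoms and a hydrogen-bond acceptor entering for one chlorine, does not move the number beyond the scatter. No available evidence accounts for this result.

Still open, as far as these compounds go, is whether an amine, a carboxylic acid or a longer chain on this carbon would stay within the scatter of compound 2. Also open, from the compounds shown here alone, is whether methoxy in place of chloro gives a similar step on other ring carbons.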